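The compounds below may be only part of what the source reports. "The series", "measured", "known", "first", "only" and "open" are said of these compounds alone.

Measured compounds:
compound 1, `CC(C)OC(=O)c1cccc(S)n1`, 132000 nM in an assay on isolated protein for inhibition of matrix metalloproteinase-9 (Homo sapiens); a higher number here means a weaker inhibitor, a lower number a stronger inhibitor
compound 2, `O=C(OCc1cccc(-c2ccccc2)c1)c1cccc(S)n1`, 50000 nM in this assay

Of the compounds shown here, two have been measured in this assay, both built on the same core. Of the two numbers, compound 2 stands lowest: the nearest is compound 1, whose number is higher by a step that lies beyond the usual scatter of this measurement. Compound 2 is therefore the stronger of the two on these numbers.

The compound that has not yet been measured is compound 3, `O=C(OCc1cccc(Oc2ccccc2)c1)c1cccc(S)n1`. It differs from compound 2 in one place: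

phenoxy in place of phenyl on an aromatic carbon

Among the compounds with values here, no step between measured compounds touches this change, so there is nothing in the numbers to say how it will turn out. The expectation is a step of no more than the scatter in either direction, given as a 1.1-fold lower number from compound 2 to compound 3 (0.05 log units; within the scatter). Compound 3 is therefore expected to give about 45000 nM in this assay, within a range from 15000 nM to 130000 nM.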

Compound 3, half-maximal inhibitory concentration: 75000 nM
Beside the measured number, compound 3's estimate is 1.7-fold (0.22 log units) below it; the measured number falls inside the stated range.
By their numbers in this assay, from the lowest: compounds 2, 3 and 1 (each within the scatter of the next, the first and the last beyond it).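

In this assay, putting phenoxy in place of phenyl gives a 1.5-fold higher number from compound 2 to compound 3 (0.18 log units; within the scatter), so on these numbers the two compounds cannot be told apart. Within the data shown here, this is the first view of what happens at this place, an aromatic carbon meta to a large group: phenoxy keeps the same six-membered aromatic ring of carbon only, adds an oxygen and a hydrogen-bond acceptor that phenyl lacks, and the two numbers still lie within the scatter of each other, so this one swap shows no clear gain or loss in this assay. Nothing available here offers an explanation for this result, and the numbers alone cannot say what the added oxygen does.

The compounds shown leave open whether the same holds for groups of a different kind at this place, such as an amine, a carboxylic acid or a longer chain like benzyloxy. Among these compounds, they also leave open whether a single swap at this place can move the number beyond the scatter in either direction, since the only step seen here stays within it.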